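The source may hold more compounds than are shown below. What is called first, only, known or untested is meant among the compounds shown, and "the series" means these compounds.

In a functional assay on MCF7 cells (Homo sapiens) for cytotoxicity, read by MTT assay, with a stated time of 48 h (a higher number here means a weaker inhibitor, a lower number a stronger inhibitor), compound 1 `C/C(=N\NC(=S)Nc1ccccc1I)c1ccccn1` gives 4.1 nM, the highest of the three numbers measured, which makes it the weakest inhibitor among them. Compound 2 `CC(=NNC(=S)Nc1ccccc1F)c1ccccn1` gives 0.39 nM, and compound 3 `C/C(=N\NC(=S)Nc1ccccc1Cl)c1ccccn1` gives 0.16 nM. Compound 4 `C/C(=N/NC(=S)Nc1ccccc1I)c1ccccn1` is the mirror case at one double bond: the two compounds have the same atoms and bonds and differ only in configuration as drawn: 1 of 1 stereo elements differ; a double bond is drawn E in compound 1 and Z in compound 4. Within the data shown here, the one measured step between compounds differing in one place is large, a 26-fold lower number from compound 1 to compound 3 (1.41 log units; beyond the scatter), but it is chloro in place of iodo on an aromatic carbon and does not touch the configuration. Among the measured compounds shown here, no measured pair isolates this double bond, so no step beyond the scatter is expected in this assay, though the uncertainty runs both ways. The estimated step is a 1.0-fold lower number from compound 1 to compound 4 (0.01 log units; within the scatter). For compound 4 the expected value is 4 nM, with a range of 0.8 nM to 20 nM.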

Compound 4, half-maximal inhibitory concentration: 4.1 nM
Estimate against measurement, compound 4: 1.0-fold (0.01 log units) below; low and high end bracket the measured number.
By their numbers in this assay, from the lowest: compound 3; then compound 2; then compounds 1 and 4 (each within the scatter of the next).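

In this assay, turning the double bond from the form drawn in compound 1 to that in compound 4 leaves the result unmoved, with no change at the digits printed from compound 1 to compound 4 (within the scatter). The earlier step, a 26-fold lower number from compound 1 to compound 3 (1.41 log units; beyond the scatter), came from chloro in place of iodo, so in this small set, changing that aromatic substituent moves the number, while changing the drawn double bond does not. This pair gives a clean reading of that one change, for a simple reason: the fact that compounds 1 and 4 differ only in the configuration as drawn

As far as these compounds go, whether compound 3, with its chloro group, would show the same indifference to the double bond remains open. So does what an amine or a carboxylic acid in place of the iodo group would give.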